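Benzyl substituent swap on a piperidine amide series

This account rests on a few compounds, and the source may have more. Where it says the series, first, only, none or still open, it means among the compounds named here.

Compound 1 `Cc1ccc(CN2CCC(NC(=O)C(C)(C)Oc3ccc(C(=O)c4ccc(Cl)cc4)cc3)CC2)cc1` gives 8560 nM. Compound 2 `Cc1ccc(C)c(OCCCC(C)(C)C(=O)NC2CCN(Cc3ccc(C(F)(F)F)cc3)CC2)c1` gives 5170 nM. Compound 3 `COc1ccc(CN2CCC(NC(=O)C(C)(C)Oc3ccc(C(=O)c4ccc(Cl)cc4)cc3)CC2)cc1` gives 4570 nM.

In a functional assay on RAW264.7 cells (Mus musculus) for inhibition, read by polymerase chain reaction, with stated times of 12 h and 6 h (on this read-out higher numbers stand for weaker inhibition and lower numbers for stronger inhibition), compound 2 stands second highest of the three numbers; its nearest neighbour is compound 3 and its furthest compound 1, and both gaps lie within the scatter. Compound 4 `Cc1ccc(CN2CCC(NC(=O)C(C)(C)CCCOc3cc(C)ccc3C)CC2)cc1` differs from compound 2 in one place: methyl in place of trifluoromethyl on an aromatic carbon. Going by the values given here, no measured pair shows this exact change. Among the compounds with values here, the only single-point step, a 1.9-fold lower number from compound 1 to compound 3 (0.27 log units; within the scatter), concerns a different group on the benzyl ring and stays within the scatter. Compound 4 is therefore expected to show no step beyond the scatter, a 1.0-fold lower number from compound 2 to compound 4 (0.01 log units; within the scatter), and is estimated at 5000 nM, between 2000 nM and 12500 nM.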

Compound 4, half-maximal inhibitory concentration: 6540 nM
Compound 4: the middle estimate sits 1.3-fold (0.12 log units) below what was measured; the range from low to high includes it.
By their numbers in this assay, from the lowest: compounds 3, 2, 4 and 1 (each within the scatter of the next).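

In this assay, replacing trifluoromethyl with methyl on the benzyl ring, para to a large group, gives a 1.3-fold higher number from compound 2 to compound 4 (0.10 log units; within the scatter). This adds a second substituent exchange at this place to a 1.9-fold lower number from compound 1 to compound 3 (0.27 log units; within the scatter), on a different core, and neither step leaves the scatter. No supporting measurement bears on this result. The compounds shown leave open whether an amine or a carboxylic acid at this place would produce a step beyond the scatter, and whether this exchange would read the same on the core of compound 1.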